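A few compounds are considered here, and "the series" means these few. Any claim that something is new, unique, unknown or untested is made for them only; others in the source may bear on it.

Compound 3 `CCOC(=O)C[C@@H]([C@H]1O[C@@H]2OC(C)(C)O[C@@H]2[C@H]1OCc1ccccc1)n1cnc2c(NCc3ccccc3)ncnc21` gives 57500 nM in an ADME assay on Vero cells (Chlorocebus sabaeus) for cytotoxicity, read by fluorescence and resazurin assay, with a stated time of 3 days (on this read-out higher numbers stand for lower toxicity in this test and lower numbers for higher toxicity in this test), and it stands alongside compound 2 `CCOC(=O)C[C@H]([C@H]1O[C@@H]2OC(C)(C)O[C@@H]2[C@H]1OCc1ccccc1)n1cnc2c(NCc3ccccc3)ncnc21` at 53300 nM and compound 1 `CC1(C)O[C@H]2O[C@H]([C@@H](CCO)n3cnc4c(N)ncnc43)[C@H](Oc3ccccc3[N+](=O)[O-])[C@H]2O1` at 51800 nM, all three within the scatter of one another in this assay. Within the data shown here, the one measured step, a 1.1-fold higher number from compound 2 to compound 3 (0.03 log units; within the scatter), shows no change beyond the scatter, and the two compounds differ only by the fact that compounds 2 and 3 differ only in the configuration as drawn. Compound 4 `CCCCCCCCCCCCNc1ncnc2c1ncn2[C@@H](CC(=O)OCC)[C@H]1O[C@@H]2OC(C)(C)O[C@@H]2[C@H]1OCc1ccccc1` differs from compound 3 by undecyl in place of phenyl on a saturated chain carbon bound to a nitrogen on an aromatic ring. Among the measured compounds shown here, no measured step swaps a ring for a long chain, so the measured steps offer no direct guide here, and with all three numbers clustered so closely the expected step of a 1.0-fold lower number from compound 3 to compound 4 (0.02 log units; within the scatter) is none beyond the scatter. Compound 4 is therefore estimated at 55000 nM in this assay, within a range from 27000 nM to 110000 nM.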

Compound 4, half-maximal cytotoxic concentration: 81500 nM
Beside the measured number, compound 4's estimate is 1.5-fold (0.17 log units) below it; the measured number falls inside the stated range.
By their numbers in this assay, from the lowest: compounds 1, 2, 3 and 4 (each within the scatter of the next).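

In this assay the swap of benzyl for dodecyl gives a 1.4-fold higher number from compound 3 to compound 4 (0.15 log units; within the scatter) and is the first change shown in the group itself, since the earlier step altered only the configuration as drawn. At this place, then, an aromatic ring gave way to a long chain with no change beyond the scatter. Nothing given here offers a reason for this result.

On these data alone, whether a shorter chain such as butyl would also stay within the scatter remains open. So does the effect of an amine or a carboxylic acid at the end of the dodecyl chain.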